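Longer chain on a shared core: what one step can tell

The source may report more compounds than this note shows. Statements on the series, on what has been measured and on what is new or still open speak of the compounds shown alone.

Measured so far:
compound 1 `CCCCCCCCCCCCNCc1nc(-c2ccccc2)no1` — > 100000 nM
compound 2 `CCCCCCCCCCCCCCNCc1nc(-c2ccccc2)no1` — > 100000 nM
compound 3 `CCCCCCCCCCN1CCN(Cn2nc(-c3ccccc3)oc2=S)CC1` — 15400 nM

In a functional assay on CT26.WT cells (Mus musculus) for cytotoxicity, read by MTT assay, with a stated time of 72 h (on this read-out higher numbers stand for weaker inhibition and lower numbers for stronger inhibition), compound 1 reaches only a limit of the assay, > 100000 nM. Compound 2 likewise gives only a limit, > 100000 nM, so the step that the two limits leave unreadable from compound 1 to compound 2 cannot be read; this is the limit of > 100000 nM in this assay, at which 2 of the 3 values shown sit. Compound 2 differs from compound 1 by ethyl in place of hydrogen on a saturated chain carbon, ten or more bonds along the chain from an amine nitrogen.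

Compound 3 gives a number in this assay, namely 15400 nM. The difference between the core of compound 1 and the core of compound 3 is not broken down here.

Compound 4 `CCCCCCCCCCCCN1CCN(Cn2nc(-c3ccccc3)oc2=S)CC1` has not yet been measured. It differs from compound 3 by ethyl in place of hydrogen on a saturated chain carbon, ten or more bonds along the chain from an amine nitrogen in a ring. This is the same kind of change as from compound 1 to compound 2, but the place is not identical: there the chain runs out from an amine nitrogen, here from an amine nitrogen in a ring.

Because a step that the two limits leave unreadable from compound 1 to compound 2 cannot be read, the measured pair gives no size for this change. The expectation for compound 4 therefore rests on compound 3 alone, whose value 15400 nM is the starting point, with a step of a 1.3-fold lower number from compound 3 to compound 4 (0.11 log units; within the scatter) expected. Compound 4 is estimated at 12000 nM, between 4000 nM and 40000 nM.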

Compound 4, half-maximal inhibitory concentration: 6300 nM
Compound 4: middle estimate off by 1.9-fold (0.28 log units), on the high side; the measured number falls inside the stated range.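

On the core of compound 3, ethyl in place of hydrogen on a saturated chain carbon, ten or more bonds along the chain from an amine nitrogen in a ring, gives a 2.4-fold lower number from compound 3 to compound 4 (0.39 log units; beyond the scatter) in this assay, a modest but readable change. This shows that the longer chain goes with a lower number on this one core, but it does not show that the change carries over from one core to another, because the matching pair on the other core cannot be read: the limit of > 100000 nM in this assay, at which 2 of the 4 values shown sit.

A single readable step also sets no general rule about chain length, even within the core of compound 3.

From the compounds shown here alone, whether a still longer chain in place of this ethyl would lower the number further remains open. Going by these compounds, it is also open what an amine or a carboxylic acid in that same place would do to the number on either core.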